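Cyclopropyl in place of methyl at a clearance limit

The source may report more compounds than this note shows. Statements on the series, on what has been measured and on what is new or still open speak of the compounds shown alone.

In a toxicity assay on microsomes from liver (Homo sapiens) for metabolic stability, read by LC-MS, using NADPH, tested at 1 uM (on this read-out higher numbers stand for fast clearance and lower numbers for slow clearance), compound 1 `COc1ncc(-c2nc(C(F)(F)F)sc2N2CCN(C(=O)Cn3nc(C)nc3C)[C@H](C)C2)cn1` gives < 10 mL.min-1.g-1, which is a limit of the assay and not a number. In this assay, compound 2 `Cc1ncc(-c2nc(C(F)(F)F)sc2N2CCN(C(=O)Cn3nc(C)nc3C)[C@H](C)C2)cn1` gives < 10 mL.min-1.g-1, which is also a limit and not a number. For the measured compounds named here, the only measured evidence on this pair is the limit of < 10 mL.min-1.g-1 in this assay, at which 2 of the 2 values shown sit. Going by the values given here, the one measured step, a step that the two limits leave unreadable from compound 1 to compound 2, is methyl in place of methoxy on an aromatic carbon, and it offers no size to carry forward. Compound 3 `Cc1nc(C)n(CC(=O)N2CCN(c3sc(C(F)(F)F)nc3-c3cnc(C4CC4)nc3)C[C@H]2C)n1` differs from compound 2 as follows: cyclopropyl in place of methyl on an aromatic carbon, between two ring nitrogen atoms. Among the compounds with values here, with no readable size to draw on, no step clearly beyond the scatter is expected, and the expected change is a step that the limit leaves unreadable from compound 2 to compound 3. In this assay, compound 3 is estimated at 9 mL.min-1.g-1, with an expected range of 4 mL.min-1.g-1 to 22 mL.min-1.g-1.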

Compound 3, intrinsic clearance in microsomes: < 10 mL.min-1.g-1
Compound 3 gave a limit, no number; the forecaster's own chance of this, stated with the estimate: 60%; the middle value lies beyond the limit too.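

Compound 1, compound 2 and compound 3 all sit at a limit of this assay and not at a number, so no step among them can be read: the limit of < 10 mL.min-1.g-1 in this assay, at which 3 of the 3 values shown sit.

The compounds shown leave open whether methoxy, methyl and cyclopropyl on the shared core differ in clearance at all.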